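A few compounds are considered here, and "the series" means these few. Any claim that something is new, unique, unknown or untested is made for them only; others in the source may bear on it.

Compound 1 `O=C(NOCc1ccccc1)c1cn(-c2ccccc2)nc1-c1ccccc1`, compound 2 `O=C(NOCc1ccccc1Cl)c1cn(-c2ccccc2)nc1-c1ccccc1` and compound 3 `COc1ccc(-c2nn(-c3ccccc3)cc2C(=O)NOCc2ccccc2)cc1` share one core and were tested in a functional assay on MCF7 cells (Homo sapiens) for antiproliferative activity, read by MTT assay, with a stated time of 48 h, in the presence of a further agent that is not named here; a lower number here means a stronger inhibitor of growth, a higher number a weaker inhibitor of growth. In this assay compound 1 gives 13400 nM, compound 2 gives 7410 nM, and compound 3 gives 2770 nM, the lowest of the three numbers. Compound 4 `COc1ccc(-c2nn(-c3ccccc3)cc2C(=O)NOCc2ccccc2Cl)cc1` has not been measured. It differs from compound 3 by chloro in place of hydrogen on an aromatic carbon. The same change has been made once before on this core: a 1.8-fold lower number from compound 1 to compound 2 (0.26 log units; within the scatter), a small drop that does not rise above the usual scatter. The other measured step, a 4.8-fold lower number from compound 1 to compound 3 (0.68 log units; beyond the scatter), concerns a different change and gives no guidance here. For compound 4 a step of a 1.5-fold lower number from compound 3 to compound 4 (0.16 log units; within the scatter) is therefore expected in this assay. The estimate for compound 4 is 1900 nM, with a range from 800 nM to 4500 nM.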

Compound 4, concentration for 50% growth inhibition: 3730 nM
The estimate for compound 4 lay 2.0-fold (0.29 log units) below the measured number, and the stated range covers the measured number.
By their numbers in this assay, from the lowest: compounds 3, 4, 2 and 1 (each within the scatter of the next, the first and the last beyond it).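

In this assay, 2-chlorobenzyl in place of benzyl gives a 1.3-fold higher number from compound 3 to compound 4 (0.13 log units; within the scatter), so on a second core this change again stays within the scatter, and the two readings of it cannot be told apart: the same change on two cores in this assay, a 1.8-fold lower number (0.26 log units; within the scatter) from compound 1 to compound 2 and a 1.3-fold higher number (0.13 log units; within the scatter) from compound 3 to compound 4, 2.4-fold (0.39 log units) apart, within the scatter of two such steps. With the chloro present, methoxy gives a 2.0-fold lower number from compound 2 to compound 4 (0.30 log units; within the scatter), which lies within the scatter, although the same change without chloro went beyond it; even so, these two readings also agree within the scatter: the same change on two cores in this assay, a 4.8-fold lower number (0.68 log units; beyond the scatter) from compound 1 to compound 3 and a 2.0-fold lower number (0.30 log units; within the scatter) from compound 2 to compound 4, 2.4-fold (0.39 log units) apart, within the scatter of two such steps.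

The compounds shown leave open whether an amine or a carboxylic acid on the same aromatic carbon would move the number beyond the scatter. Going by these compounds, a longer chain in place of benzyl also remains untested here.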